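A few compounds are considered here, and "the series" means these few. Any claim that something is new, unique, unknown or untested is made for them only; others in the source may bear on it.

Measured in a physicochemical assay for lipophilicity, using the shake flask method, in phosphate buffer, measured as octanol-water partition, with a stated time of 30 min, at pH 7.4; on this read-out lower numbers stand for lower lipophilicity and higher numbers for higher lipophilicity:
- compound 1 (`Cc1nccn1-c1cnc(NCc2c(F)ccc3c2CCO3)c2cn[nH]c(=O)c12`): 2.1
- compound 2 (`CN(C)C(=O)c1cc(-c2cnc(NCc3c(F)ccc4c3CCO4)c3cn[nH]c(=O)c23)n(C)n1`): 2.1
- compound 3 (`CNC(=O)c1cc(-c2cnc(NCc3c(F)ccc4c3CCO4)c3cn[nH]c(=O)c23)n(C)n1`): 2.1

Among the compounds with values here, compound 3 stands level with compounds 1 and 2, and the series so far is flat on this read-out. The next step leads to compound 4 (`Cc1nn(C)cc1-c1cnc(NCc2c(F)ccc3c2CCO3)c2cn[nH]c(=O)c12`), where 1,3-dimethyl-1H-pyrazol-4-yl replaces 1-methyl-3-(methylcarbamoyl)-1H-pyrazol-5-yl on an aromatic carbon (1,3-dimethyl-1H-pyrazol-4-yl in place of 1-methyl-3-(methylcarbamoyl)-1H-pyrazol-5-yl on an aromatic carbon).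

Within the data shown here, three measured steps bear on this: no change at the digits printed from compound 1 to compound 2 (within the scatter), no change at the digits printed from compound 1 to compound 3 (within the scatter) and no change at the digits printed from compound 2 to compound 3 (within the scatter). Among the measured compounds shown here, the last touches only the amide nitrogen, while the first two exchange one group for another on an aromatic carbon and are the closer precedents. None of them removes the methylcarbamoyl group while keeping a pyrazole, so they constrain the new step only loosely, and the range stays wide.

A small upward move is expected, possibly not beyond the scatter, with the estimated step being a number 0.20 log units higher from compound 3 to compound 4 (within the scatter). For compound 4 the estimated value is 2.3, with an expected range from 1.9 to 2.8.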

Compound 4, distribution coefficient: 2.8
Estimate against measurement, compound 4: 0.50 log units below; low and high end bracket the measured number.
By their numbers in this assay, from the lowest: compounds 1, 2 and 3 (each within the scatter of the next); then compound 4.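

In this assay, this position on the six-membered aromatic ring proves able to move the read-out, which compounds 1, 2 and 3 among themselves did not show: 1,3-dimethyl-1H-pyrazol-4-yl gives a number 0.70 log units higher from compound 3 to compound 4 (beyond the scatter), and likewise a number 0.70 log units higher from compound 2 to compound 4 (beyond the scatter). Against 2-methyl-1H-imidazol-1-yl the same group gives a number 0.70 log units higher from compound 1 to compound 4 (beyond the scatter), so it stands apart from all three groups that sit level with one another. Nothing measured here accounts for the step.

On these data alone, the change from compound 3 to compound 4 removes the methylcarbamoyl group and shifts the ring attachment from the 5-yl to the 4-yl together, so which of the two carries the step stays open. Also open, as far as these compounds go, is how the read-out responds at this position to a pyrazole bearing an amine or a carboxylic acid.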